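Series notes: from compound 3 to compound 4

The compounds below may be only part of what the source reports. "The series", "measured", "known", "first", "only" and "open" are said of these compounds alone.

Measured compounds, in a functional assay on Jurkat cells (Homo sapiens) for inhibition; on this read-out lower numbers stand for stronger inhibition and higher numbers for weaker inhibition:
- compound 1 `CCOC(=O)c1cnc(NN2C(=O)C=C(C)C2=O)nc1C`: 1900 nM
- compound 2 `CCOC(=O)c1cnc(NN2C(=O)C=C(C)C2=O)nc1Cc1ccccc1`: 3800 nM
- compound 3 `CCOC(=O)c1cnc(NN2C(=O)C=C(C)C2=O)nc1COC`: 6000 nM

Compound 3 carries the highest number of the three. Its nearest neighbour is compound 2, and the gap is described by a 1.6-fold higher number from compound 2 to compound 3 (0.20 log units; within the scatter). The gap to compound 1 is described by a 3.2-fold higher number from compound 1 to compound 3 (0.50 log units; beyond the scatter).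

Compound 4 `CCOC(=O)c1cnc(NN2C(=O)C=C(C)C2=O)nc1-c1cc2ccccc2s1` arises from compound 3 by 1-benzothiophen-2-yl in place of methoxymethyl on an aromatic carbon.

For the measured compounds named here, no measured step changes a substituent on an aromatic carbon in this way. The steps available change a group on a saturated chain carbon: a 2.0-fold higher number from compound 1 to compound 2 (0.30 log units; within the scatter) and a 3.2-fold higher number from compound 1 to compound 3 (0.50 log units; beyond the scatter), and between the two larger groups, a 1.6-fold higher number from compound 2 to compound 3 (0.20 log units; within the scatter). Enlargement from hydrogen to phenyl or methoxy gave no lowering of the number, and none of these steps exceeds a modest size. For compound 4 a step of about a 1.5-fold lower number from compound 3 to compound 4 (0.18 log units; within the scatter) in this assay is therefore expected, without confidence in its direction. Compound 4 is estimated at 4000 nM, in the range 1300 nM to 12000 nM.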

Compound 4, half-maximal inhibitory concentration: 800 nM
For compound 4 the middle estimate is 5.0-fold (0.70 log units) above the measured one; measured number outside the range, below it.
By their numbers in this assay, from the lowest: compound 4; then compounds 1, 2 and 3 (each within the scatter of the next, the first and the last beyond it).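

In this assay, the aromatic carbon next to the ring nitrogen and ortho to the ethoxycarbonyl group now gives a lowering of the number, with a 7.5-fold lower number from compound 3 to compound 4 (0.88 log units; beyond the scatter), a 4.8-fold lower number from compound 2 to compound 4 (0.68 log units; beyond the scatter) and a 2.4-fold lower number from compound 1 to compound 4 (0.38 log units; beyond the scatter), all beyond the scatter. The earlier changes at this place gave no lowering, so a larger group here is not in itself linked to a higher number: 1-benzothiophen-2-yl brings 9 heavy atoms and two aromatic rings in place of the 3 heavy atoms of methoxymethyl. No supporting data bear on why the number falls.

Open, from the compounds shown here alone, is whether the lowering needs both rings or the sulfur, which a directly bound phenyl, thiophen-2-yl or 1-benzofuran-2-yl at this place would separate. Also open, going by these compounds, is whether it survives exchange of the ethoxycarbonyl group for a carboxylic acid or an amide.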